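The source may report more compounds than this note shows. Statements on the series, on what has been measured and on what is new or still open speak of the compounds shown alone.

Within the data shown here, in an ADME assay on CEM-SS cells (Homo sapiens) for cytotoxicity, read by XTT assay (a higher number here means that more compound is tolerated, a lower number that less compound is tolerated), compound 1 `CCCc1c(C)sc2nc(-c3ccc(O)c(O)c3)[nH]c(=O)c12` gives 11200 nM, the lower of the two numbers measured so far. Compound 2 `CCCCc1c(C)sc2nc(-c3ccc(O)c(O)c3)[nH]c(=O)c12` gives 25400 nM. Compound 3 `CCCc1c(CC)sc2nc(-c3ccc(O)c(O)c3)[nH]c(=O)c12` has not yet been measured. It differs from compound 1 as follows: methyl in place of hydrogen on a saturated chain carbon bound to an aromatic carbon. That is, methyl in place of hydrogen on a saturated chain carbon bound to an aromatic carbon. Among the measured compounds shown here, the only measured step bearing on this change is a 2.3-fold higher number from compound 1 to compound 2 (0.36 log units; beyond the scatter). That step also puts methyl in place of hydrogen, but on a saturated chain carbon, three bonds along the chain from an aromatic carbon, so it is a single and indirect guide. A small move towards a higher number is expected, possibly not clearing the scatter. The expected step is a 1.6-fold higher number from compound 1 to compound 3 (0.21 log units; within the scatter). For compound 3 the estimated value is 18000 nM, with an expected range of 8000 nM to 40000 nM.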

Compound 3, half-maximal cytotoxic concentration: 33700 nM
Estimate against measurement, compound 3: 1.9-fold (0.27 log units) below; measured number inside the range.
By their numbers in this assay, from the lowest: compound 1; then compounds 2 and 3 (each within the scatter of the next).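

In this assay, methyl to ethyl on a saturated chain carbon bound to an aromatic carbon gives a 3.0-fold higher number from compound 1 to compound 3 (0.48 log units; beyond the scatter) and so shows that this position also responds to a single added methyl. The earlier change, on a saturated chain carbon three bonds along the chain from an aromatic carbon, gave a 2.3-fold higher number from compound 1 to compound 2 (0.36 log units; beyond the scatter) in the same direction, so both places shown move towards more compound tolerated, and no compound shown goes against this. Nothing on hand bears on the reason for this shift.

From the compounds shown here alone, whether a longer chain, such as propyl, or a chain ending in an amine or a carboxylic acid at this carbon would continue the trend remains open. Also open, going by these compounds, is how the ethyl and butyl changes would read together in one compound.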